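The compounds below may be only part of what the source reports. "The series", "measured", "known", "first", "only" and "open" are said of these compounds alone.

Going by the values given here, in a functional assay on LNCaP cells (Homo sapiens) for antiproliferative activity, read by propidium iodide staining, with a stated time of 96 h (a higher number here means a weaker inhibitor, a lower number a stronger inhibitor), compound 2 `CC(O)(CS(=O)(=O)c1ccc(F)cc1)C(=O)Nc1ccc(S(F)(F)(F)(F)F)cc1` gives 18200 nM, the lower of the two numbers so far, yet compound 1 `CC(O)(CS(=O)(=O)c1ccc(S(F)(F)(F)(F)F)cc1)C(=O)Nc1ccc(S(F)(F)(F)(F)F)cc1` at 29200 nM lies within the scatter of it. Compound 3 `CC(O)(CS(=O)(=O)c1ccc(C(F)(F)F)cc1)C(=O)Nc1ccc(S(F)(F)(F)(F)F)cc1` differs from compound 2 by trifluoromethyl in place of fluoro on an aromatic carbon, para to a large group. Among the compounds with values here, the only measured step at this place, a 1.6-fold lower number from compound 1 to compound 2 (0.21 log units; within the scatter), stayed within the scatter, so no step beyond the scatter is expected in this assay. The expected step is a 1.1-fold higher number from compound 2 to compound 3 (0.04 log units; within the scatter). Compound 3 is estimated at 20000 nM, with a range of 10000 nM to 38000 nM.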

Compound 3, half-maximal inhibitory concentration: 20700 nM
Estimate against measurement, compound 3: 1.0-fold (0.01 log units) below; low and high end bracket the measured number.
By their numbers in this assay, from the lowest: compounds 2, 3 and 1 (each within the scatter of the next).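

With a third group at this place, on an aromatic carbon para to a large group, the change from 4-fluorophenyl to 4-(trifluoromethyl)phenyl in this assay gives a 1.1-fold higher number from compound 2 to compound 3 (0.06 log units; within the scatter), and replacing the larger group with trifluoromethyl gives a 1.4-fold lower number from compound 1 to compound 3 (0.15 log units; within the scatter). All three compounds now lie within the scatter of one another, so this assay separates none of these groups at this place. Nothing available bears on the reason for this. As far as these compounds go, all three groups contain fluorine; whether an amine or a carboxylic acid here would give a step beyond the scatter remains open.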